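The source may hold more compounds than are shown below. What is called first, only, known or untested is meant among the compounds shown, and "the series" means these compounds.

Of the compounds shown here, two built on a shared core have been tested in a functional assay on A549 cells (Homo sapiens) for antiproliferative activity, read by MTT assay, with a stated time of 24 h; on this read-out lower numbers stand for stronger inhibition and higher numbers for weaker inhibition. Compound 1 `COc1ccc(/C=C/C(=O)c2cc(-c3ccc(OC)c(OC)c3)n3nc(-c4ccccc4)cc3n2)cc1` gives 19300 nM. Compound 2 `COc1cc(-c2cc(/C=C/C(=O)c3ccc(C)c(C)c3)nc3cc(-c4ccccc4)nn23)cc(OC)c1OC` gives 10600 nM in this assay. Compound 2 shows the lower of the two readings, but compound 1 lies within the usual scatter of it, so the pair cannot be told apart. Compound 3 `COc1ccc(/C=C/C(=O)c2cc(-c3cc(OC)c(OC)c(OC)c3)n3nc(-c4ccccc4)cc3n2)cc1` has not yet been measured. It differs from compound 2 in one place: (2-(4-methoxyphenyl)ethenyl)carbonyl in place of 2-((3,4-dimethylphenyl)carbonyl)ethenyl on an aromatic carbon. Among the measured compounds shown here, no measured pair shows this change on its own. Compound 3 carries the same side chain as compound 1 together with the 3,4,5-trimethoxyphenyl group of compound 2, so its reading is expected to fall between that of compound 1, 19300 nM, and that of compound 2, 10600 nM. The step from compound 2 to compound 3 in this assay is estimated at a 1.4-fold higher number from compound 2 to compound 3 (0.15 log units; within the scatter), not beyond the scatter. Compound 3 is expected to give 15000 nM in this assay, within a range from 5000 nM to 45000 nM.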

Compound 3, half-maximal inhibitory concentration: 21200 nM
Estimate against measurement, compound 3: 1.4-fold (0.15 log units) below, and the stated range covers the measured number.
By their numbers in this assay, from the lowest: compounds 2, 1 and 3 (each within the scatter of the next).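

In this assay, putting (2-(4-methoxyphenyl)ethenyl)carbonyl in place of 2-((3,4-dimethylphenyl)carbonyl)ethenyl on this aromatic carbon gives a 2.0-fold higher number from compound 2 to compound 3 (0.30 log units; within the scatter), so this first direct look at the swap shows no effect that can be separated from assay noise. Methoxy in place of hydrogen on an aromatic carbon, which completes the 3,4,5-trimethoxyphenyl group, gives a 1.1-fold higher number from compound 1 to compound 3 (0.04 log units; within the scatter) and likewise shows no clear effect. No measurement at hand explains these readings.

The swap reverses the order of the carbonyl and ethenyl parts and also alters the groups on the benzene ring, so even a larger step could not have been pinned on either alteration alone. As far as these compounds go, whether an amine or a carboxylic acid at the end of this side chain would give a clearly different reading remains open.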